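Varying the Amide Aryl Group: Three Measured, One Expected

The source may report more compounds than this note shows. Statements on the series, on what has been measured and on what is new or still open speak of the compounds shown alone.

Three compounds sharing one core were tested in a functional assay on HepG2 cells (Homo sapiens) for antiproliferative activity, read by CCK-8 assay, with a stated time of 72 h; on this read-out lower numbers stand for stronger inhibition and higher numbers for weaker inhibition:
compound 1 `O=C(Nc1cccc(-c2oc3cc(-c4ccc(F)cc4)ccc3c(=O)c2O)c1)c1ccc(Br)cc1` gives 13900 nM;
compound 2 `Cc1cc(C(=O)Nc2cccc(-c3oc4cc(-c5ccc(F)cc5)ccc4c(=O)c3O)c2)ccc1F` gives 9540 nM;
compound 3 `COc1ccc(C(=O)Nc2cccc(-c3oc4cc(-c5ccc(F)cc5)ccc4c(=O)c3O)c2)c(F)c1` gives 45300 nM.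

Compound 3 stands highest of the three numbers. The steps of a 3.3-fold higher number from compound 1 to compound 3 (0.51 log units; beyond the scatter) and a 4.7-fold higher number from compound 2 to compound 3 (0.68 log units; beyond the scatter) both go beyond the scatter, whereas a 1.5-fold lower number from compound 1 to compound 2 (0.16 log units; within the scatter) does not, so the 4-bromophenyl and 4-fluoro-3-methylphenyl amides cannot be told apart, while the 2-fluoro-4-methoxyphenyl amide is weaker than either. Compound 4 `Cc1cc(C)cc(C(=O)Nc2cccc(-c3oc4cc(-c5ccc(F)cc5)ccc4c(=O)c3O)c2)c1` has not yet been measured. It differs from compound 3 by 3,5-dimethylphenyl in place of 2-fluoro-4-methoxyphenyl on a carbonyl carbon. The two steps leading into compound 3 bear on this change: each swapped a substituted phenyl without a methoxy group for the 2-fluoro-4-methoxyphenyl and raised the number modestly. Moving back to a dimethyl-substituted phenyl should therefore undo part of that rise, giving a modest downward step rather than none. Compound 4 is expected to give 12000 nM, in the range 5000 nM to 30000 nM. The expected step is a 3.8-fold lower number from compound 3 to compound 4 (0.58 log units; beyond the scatter).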

Compound 4, half-maximal inhibitory concentration: 13400 nM
Compound 4: middle estimate off by 1.1-fold (0.05 log units), on the low side, within the range that was stated.
By their numbers in this assay, from the lowest: compounds 2, 4 and 1 (each within the scatter of the next); then compound 3.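

In this assay the step of a 3.4-fold lower number from compound 3 to compound 4 (0.53 log units; beyond the scatter) places the 3,5-dimethylphenyl amide with the other two rather than with the 2-fluoro-4-methoxyphenyl amide, so a third aryl group at this carbonyl carbon does not share the weaker result. The steps of a 1.4-fold higher number from compound 2 to compound 4 (0.15 log units; within the scatter) and a 1.0-fold lower number from compound 1 to compound 4 (0.02 log units; within the scatter) both lie within the scatter, and the 4-bromophenyl, 4-fluoro-3-methylphenyl and 3,5-dimethylphenyl amides cannot be told apart despite their different substituents, which leaves compound 3 alone apart from them. No evidence is available to explain this difference.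

The compounds shown leave open whether the result for compound 3 belongs to its methoxy group or its fluorine, which leave together in this change. They also leave open what an unsubstituted phenyl, or an amine or carboxylic acid on this aryl ring, would give.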